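A few compounds are considered here, and "the series" means these few. Any claim that something is new, unique, unknown or untested is made for them only; others in the source may bear on it.

Measured compounds:
compound 1, `C=C1C(=O)O[C@]2(C)CC[C@@H]1C[C@H](O)[C@@]1(C)CC[C@H](OC(C)=O)[C@@](C)(CCC2=O)O1`: > 20 ug/mL
compound 2, `C=C1C(=O)O[C@]2(C)CC[C@@H]1C[C@H](O)[C@@]1(C)CC[C@H](O1)[C@](C)(O)CC[C@H]2OC(C)=O`: > 20 ug/mL

Of the compounds shown here, two have been tested so far. In a functional assay on HeLa cells (Homo sapiens) for cytotoxicity (a higher number here means a weaker inhibitor, a lower number a stronger inhibitor), compound 1 gives > 20 ug/mL, which is a limit of the assay and not a number. Compound 2 gives > 20 ug/mL in this assay, again only a limit. Compound 2 therefore stands at the limit of > 20 ug/mL in this assay, at which 2 of the 2 values shown sit, and nothing on the numbers shown separates it from compound 1. Within the data shown here, no step between measured compounds that differ in one place is available.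

Compound 3, `C=C1C(=O)O[C@]2(C)CC[C@@H]1C[C@H](OC(C)=O)[C@@]1(C)CC[C@H](O1)[C@](C)(O)CC[C@H]2OC(C)=O`, has not yet been measured in this assay. It differs from compound 2 in one place:
acetyl in place of hydrogen on an oxygen on a saturated carbon
Both measured values sit at the limit of > 20 ug/mL in this assay, at which 2 of the 2 values shown sit, so for compound 3 the step that the limit leaves unreadable from compound 2 to compound 3 is expected to lie within the scatter, in neither direction. Compound 3 is accordingly estimated at 25 ug/mL, between 12 ug/mL and 50 ug/mL, with a limit again the most likely report.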

Compound 3, half-maximal inhibitory concentration: > 20 ug/mL
Compound 3 was reported as a limit; the forecaster's own chance of this, stated with the estimate: 75%; the middle value is on the limit's open side.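

Compound 2 and compound 3 are each reported only as a limit, so no step between them can be read: the limit of > 20 ug/mL in this assay, at which 3 of the 3 values shown sit.

The compounds shown leave open where the true value of any of them lies in this assay, and so whether replacing hydroxy with acetoxy changes anything.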